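Oxazoline to thiazoline swap on a sulfonylmethyl side chain

The source may hold more compounds than are shown below. What is called first, only, known or untested is meant among the compounds shown, and "the series" means these compounds.

Compound 1 `O=S(=O)(CC1=NCCO1)c1c(-c2ccccc2)nn(-c2ccccc2)c1-c1ccccc1` carries a sulfonyl-linked side chain on a core bearing three phenyl rings. In a functional assay, read by Griess assay, with a stated time of 150 min, tested at 100 ug/mL (a higher number here means a stronger effect of the compound at the concentration tested, a lower number a weaker effect), compound 1 gives 63.5%, the highest of the three measured numbers. Compound 2 `Cc1ccc(C2CNN=C2S(=O)(=O)CC2=NCCS2)cc1` and compound 3 `Cc1ccc(C2CNN=C2S(=O)(=O)CC2=NCCO2)cc1` share a different core; the difference between the two cores is not broken down here. In this assay compound 2 gives 52.2%, and compound 3 gives 51.4%. Compound 2 and compound 3 differ in one place: a group of 5 heavy atoms (3 carbon, 1 nitrogen, 1 sulfur; one five-membered non-aromatic ring with 2 hetero atoms) in place of a group of 5 heavy atoms (3 carbon, 1 nitrogen, 1 oxygen; one five-membered non-aromatic ring with 2 hetero atoms), on a saturated chain carbon bound to a sulfonyl sulfur. This change made a step of a number 0.8 percentage points higher from compound 3 to compound 2 (within the scatter).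

Compound 4 `O=S(=O)(CC1=NCCS1)c1c(-c2ccccc2)nn(-c2ccccc2)c1-c1ccccc1` has not yet been measured. It differs from compound 1 by the same change: a group of 5 heavy atoms (3 carbon, 1 nitrogen, 1 sulfur; one five-membered non-aromatic ring with 2 hetero atoms) in place of a group of 5 heavy atoms (3 carbon, 1 nitrogen, 1 oxygen; one five-membered non-aromatic ring with 2 hetero atoms), on a saturated chain carbon bound to a sulfonyl sulfur. Because the same change gave a number 0.8 percentage points higher from compound 3 to compound 2 (within the scatter), a step of about the same size is expected for compound 4, estimated as a number 0.5 percentage points higher from compound 1 to compound 4 (within the scatter). On that basis compound 4 is expected to give about 64% in this assay, with an estimated range from 54% to 74%.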

Compound 4, a percentage reported as activity, at one concentration (the size of the read-out at that concentration, not a potency): "not active" (no number reported)
Compound 4 has no reported number here; no gap can be computed for the estimate.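

In this assay, for the compounds shown here, compound 4 is reported as not active, with no number, so no step from compound 1 to compound 4 can be read. The compounds shown leave open how far compound 4 actually lies from compound 1, and whether the same change behaves differently on the two cores. Nothing given here bears on the reason for this result.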